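Hydroxyethyl to cyclopropylcarbamoyl on the saturated chain

The source may hold more compounds than are shown below. What is called first, only, known or untested is meant among the compounds shown, and "the series" means these compounds.

Compound 1 `Cn1ncc(Cl)c1-c1cc(C(=O)N[C@@H]2CN[C@H](CC(O)CO)C[C@H]2c2ccc(F)c(F)c2)oc1Cl`: 690 nM
Compound 2 `Cn1ncc(Cl)c1-c1cc(C(=O)N[C@@H]2CN[C@H](CCCO)C[C@H]2c2ccc(Cl)c(Cl)c2)oc1Cl`: 600 nM

In a functional assay on OVCAR-8 cells (Homo sapiens) for antiproliferative activity (on this read-out lower numbers stand for stronger inhibition and higher numbers for weaker inhibition), compound 2 gives 600 nM, and compound 1 gives 690 nM; these two values lie within the scatter of one another, so neither stands apart. Compound 3 `Cn1ncc(Cl)c1-c1cc(C(=O)N[C@@H]2CN[C@H](CC(=O)NC3CC3)C[C@H]2c2ccc(Cl)c(Cl)c2)oc1Cl` differs from compound 2 in one place: cyclopropylcarbamoyl in place of 2-hydroxyethyl on a saturated chain carbon bound to a saturated ring carbon. Within the data shown here, no measured pair shows this change, so its effect is unknown. The step of no change at the digits printed from compound 2 to compound 3 (within the scatter) is expected to stay within the scatter, with no clear direction. Compound 3 is estimated at 600 nM, with a range from 200 nM to 1800 nM.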

Compound 3, half-maximal inhibitory concentration: 580 nM
Compound 3: the middle estimate sits 1.0-fold (0.01 log units) above what was measured; low and high end bracket the measured number.
By their numbers in this assay, from the lowest: compounds 3, 2 and 1 (each within the scatter of the next).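

Putting cyclopropylcarbamoyl in place of 2-hydroxyethyl on a saturated chain carbon bound to a saturated ring carbon brings a 1.0-fold lower number from compound 2 to compound 3 (0.01 log units; within the scatter) in this assay, so this position takes a group with a three-membered ring and a carbonyl without a readable shift. Compound 1 and compound 2 differ in more than one place and could not show this. Nothing measured here explains the result. On these data alone, whether an amine, a carboxylic acid or a longer chain at this position would also leave the number within the scatter stays open.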